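Benzyl change from compound 2 to compound 3

The source may report more compounds than this note shows. Statements on the series, on what has been measured and on what is new or still open speak of the compounds shown alone.

In a functional assay on NCI-H460 cells (Homo sapiens) for cytotoxicity, read by MTT assay, with a stated time of 72 h (on this read-out lower numbers stand for stronger inhibition and higher numbers for weaker inhibition), compound 1 `Cc1ccc(Cn2cc(/C=N/NC(=O)Nc3nc4ccc(CN(C)C)cc4s3)c3ccccc32)cc1` gives 200 nM, and compound 2 `CN(C)Cc1ccc2nc(NC(=O)N/N=C/c3cn(Cc4cccc(Cl)c4)c4ccccc34)sc2c1` gives 420 nM. Compound 2 therefore holds the higher of the two numbers, which makes it the weaker of this pair on this read-out.

The unmeasured compound 3 `CN(C)Cc1ccc2nc(NC(=O)N/N=C/c3cn(Cc4ccc(Cl)cc4Cl)c4ccccc34)sc2c1` keeps the shared core and differs from compound 2 in one place, on a saturated chain carbon bound to an aromatic nitrogen: 2,4-dichlorophenyl in place of 3-chlorophenyl on a saturated chain carbon bound to an aromatic nitrogen. Read one bond further out, this is 3-chlorobenzyl to 2,4-dichlorobenzyl.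

Within the data shown here, only one measured step bears on this position, the exchange of 4-methylphenyl for 3-chlorophenyl: a 2.1-fold higher number from compound 1 to compound 2 (0.32 log units; beyond the scatter). Among the measured compounds shown here, that step is modest, and no measured pair contains the 2,4-dichlorophenyl group. The data therefore give no firm direction, and no step beyond the scatter is expected in this assay. The expected step is a 1.2-fold lower number from compound 2 to compound 3 (0.08 log units; within the scatter). The estimated value for compound 3 is 350 nM, with an expected range from 120 nM to 1000 nM.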

Compound 3, half-maximal inhibitory concentration: 950 nM
Estimate against measurement, compound 3: 2.7-fold (0.43 log units) below, within the range that was stated.
By their numbers in this assay, from the lowest: compound 1; then compound 2; then compound 3.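

In this assay the position on a saturated chain carbon bound to an aromatic nitrogen now gives a second step beyond the scatter: 2,4-dichlorophenyl in place of 3-chlorophenyl gives a 2.3-fold higher number from compound 2 to compound 3 (0.35 log units; beyond the scatter), so this position is shown to respond to a change between two chlorinated groups, not only to the exchange of 4-methylphenyl for 3-chlorophenyl. Against 4-methylphenyl, the same group gives a 4.8-fold higher number from compound 1 to compound 3 (0.68 log units; beyond the scatter), the largest step in the set, which places the three groups in one order from the lowest number to the highest (4-methylphenyl, 3-chlorophenyl, 2,4-dichlorophenyl), and compound 3 is the weakest of the three on this read-out, with no compound shown going against that order. Nothing measured here accounts for this order.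

Still open, from the compounds shown here alone, is whether the order extends to groups outside this set, such as an unsubstituted phenyl, a 4-chlorophenyl or a 2-chlorophenyl at the same place. Also open, going by these compounds, is how a phenyl carrying an amine or a carboxylic acid, or a longer chain in place of the single saturated carbon, would stand.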